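Methyl on the Carbamoyl Chain in a Weak MCF7 Series

This account rests on a few compounds, and the source may have more. Where it says the series, first, only, none or still open, it means among the compounds named here.

Compound 1 `CCNC(=O)N1CCN(C(=S)SCc2cn(Cc3ccc(Cl)cc3)nn2)CC1`: in a functional assay on MCF7 cells (Homo sapiens) for cytotoxicity, read by MTT assay, with a stated time of 72 h (on this read-out lower numbers stand for stronger inhibition and higher numbers for weaker inhibition), compound 1 gives > 128000 nM, which is a limit of the assay and not a number.
Compound 2 `CC(C)NC(=O)N1CCN(C(=S)SCc2cn(Cc3ccc(Cl)cc3)nn2)CC1`: in this assay compound 2 gives > 128000 nM, again a limit rather than a number.
For the measured compounds named here, compound 3 `CCNC(=O)N1CCN(C(=S)SCc2cn(Cc3ccc(OC)cc3)nn2)CC1`: in this assay compound 3 gives 97600 nM, the only true number in the set.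

Compound 1 and compound 2 differ by methyl in place of hydrogen on a saturated chain carbon bound to an amide-type nitrogen and a saturated chain carbon. The step that the two limits leave unreadable from compound 1 to compound 2 cannot be sized because of the limit of > 128000 nM in this assay, at which 2 of the 3 values shown sit. Compound 1 and compound 3 differ in their cores by methoxy in place of chloro on an aromatic carbon, and the step of an at least 1.3-fold lower number from compound 1 to compound 3 (0.11 log units; that floor lies within the scatter) is the only readable movement in the data.

Compound 4 `COc1ccc(Cn2cc(CSC(=S)N3CCN(C(=O)NC(C)C)CC3)nn2)cc1` is not yet measured. Compound 3 and compound 4 differ by methyl in place of hydrogen on a saturated chain carbon bound to an amide-type nitrogen and a saturated chain carbon. This is the same change that turns compound 1 into compound 2, made on the core of compound 3 instead, and it sits at a place described in identical words in both pairs. The earlier instance of this change left both values at a limit and so gives no direction to borrow. The expectation for compound 4 therefore rests on compound 3 alone, which gives 97600 nM. Compound 4 is therefore expected to show a step of a 1.1-fold higher number from compound 3 to compound 4 (0.05 log units; within the scatter), within the usual scatter, and its estimated value in this assay is 110000 nM, with a fair chance that only a limit is returned.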

Compound 4, half-maximal inhibitory concentration: 19600 nM
Compound 4: the middle estimate sits 5.6-fold (0.75 log units) above what was measured; measured number below the stated range.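

In this assay, the change from ethyl to isopropyl on the carbamoyl chain gives a 5.0-fold lower number from compound 3 to compound 4 (0.70 log units; beyond the scatter), so on this core the added methyl goes with a real drop in the number. The same change on the chloro-bearing core of compound 1 cannot be read, and it therefore cannot be said whether the methyl step carries from one core to the other, because both of its ends stop at a limit of the assay, not at a number: (the limit of > 128000 nM in this assay, at which 2 of the 4 values shown sit). The swap of chloro for methoxy, now seen with the isopropyl group in place, gives an at least 6.5-fold lower number from compound 2 to compound 4 (0.81 log units; beyond the scatter) in this assay, but this does not establish that the swap acts more strongly on one core than on the other: (the same change on two cores in this assay, an at least 1.3-fold lower number (0.11 log units; that floor lies within the scatter) from compound 1 to compound 3 and an at least 6.5-fold lower number (0.81 log units; beyond the scatter) from compound 2 to compound 4; the limit leaves it open whether they differ).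

The compounds shown leave open how a longer chain such as butyl, or a cyclopropyl group, would read in place of the ethyl or isopropyl on the carbamoyl chain. They also leave open whether the methyl step would hold with a different group, such as an amine or a carboxylic acid, in place of methoxy on that aromatic carbon.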